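The source may report more compounds than this note shows. Statements on the series, on what has been measured and on what is new or still open speak of the compounds shown alone.

Measured compounds:
- compound 1, `Cc1c(C(=O)N=C(N)N)ccc(Cl)c1S(C)(=O)=O`: 1300 nM
- compound 2, `Cc1c(C(=O)N=C(N)N)cc(S(C)(=O)=O)c(C)c1C`: 55 nM
- compound 3, `Cc1cc(-c2ccc(Cl)cc2Cl)c(S(C)(=O)=O)cc1C(=O)N=C(N)N`: 42 nM

In a functional assay for inhibition of sodium/hydrogen exchanger (Oryctolagus cuniculus) (on this read-out lower numbers stand for stronger inhibition and higher numbers for weaker inhibition), compound 3 gives the lowest of the three numbers. Compound 2 comes nearest to it, and the gap between compound 3 and compound 2 lies within the scatter, so the two cannot be placed in any order. Compound 1 stands furthest away, and its gap to compound 3 lies beyond the scatter.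

Compound 4, `Cc1cc(OC(C)C)c(S(C)(=O)=O)cc1C(=O)N=C(N)N`, has not yet been measured in this assay. It differs from compound 3 in one place: isopropoxy in place of 2,4-dichlorophenyl on an aromatic carbon. The group that enters sits on an aromatic carbon of a six-membered aromatic ring of carbon only, ortho to a methylsulfonyl group and para to a group of six heavy atoms.

Going by the values given here, no measured pair shows this change, so the size of the step is open. Compound 4 is expected to stay close to compound 3, with a step of a 1.9-fold higher number from compound 3 to compound 4 (0.28 log units; within the scatter) that is roughly within the scatter or slightly towards weaker inhibition. The estimate for compound 4 in this assay is 80 nM, with a range from 25 nM to 300 nM.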

Compound 4, half-maximal inhibitory concentration: 19 nM
For compound 4 the middle estimate is 4.2-fold (0.62 log units) above the measured one, and the stated range ends above it.
By their numbers in this assay, from the lowest: compound 4; then compounds 3 and 2 (each within the scatter of the next); then compound 1.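

In this assay, placing isopropoxy in place of 2,4-dichlorophenyl on this aromatic carbon, ortho to a methylsulfonyl group, gives a 2.2-fold lower number from compound 3 to compound 4 (0.34 log units; beyond the scatter) and so counts as a modest gain in inhibition. The position therefore does not depend on the ring of compound 3: a group with no ring and 4 heavy atoms instead of 8 does at least as well here, and one hydrogen-bond acceptor enters where none stood. No measurement at hand explains the step, and this single pair cannot separate the loss of the ring from the entry of the oxygen.

On these data alone, whether other groups on this carbon follow the same course remains open, for example methoxy, a longer chain such as butoxy, or an amine. An isopropyl group bonded directly through carbon would show whether the oxygen matters at all.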